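Swapping a Ring-Bearing Chain for Isopropyl

The source may hold more compounds than are shown below. What is called first, only, known or untested is meant among the compounds shown, and "the series" means these compounds.

compound 1 `CS(=O)(=O)Nc1ccc2c(c1)S(=O)(=O)N=C(C1=C(O)C3CCCC3N(CCC3CC3)C1=O)N2` > 33000 nM
compound 2 `CS(=O)(=O)Nc1ccc2c(c1)S(=O)(=O)N=C(C1=C(O)[C@H]3CCCC[C@H]3N(Cc3ccc(F)cc3)C1=O)N2` > 1000 nM

In an ADME assay on Huh-7 cells (Homo sapiens) for cytotoxicity, with a stated time of 72 h (a higher number here means that more compound is tolerated, a lower number that less compound is tolerated), compound 1 gives only a limit, > 33000 nM, not a number. Compound 2 likewise gives only a limit, > 1000 nM. Both readings are limits, so compound 1 cannot be ranked against compound 2 on these numbers. The untested compound 3 `CC(C)N1C(=O)C(C2=NS(=O)(=O)c3cc(NS(C)(=O)=O)ccc3N2)=C(O)C2CCCC21` differs from compound 1 by isopropyl in place of 2-cyclopropylethyl on an amide-type nitrogen in a ring. Among the measured compounds shown here, no measured pair isolates this change, so a step no larger than the usual scatter is expected, in no set direction. Compound 3 is expected to give 50000 nM, within 20000 nM to 150000 nM, which is an expected step that the limit leaves unreadable from compound 1 to compound 3.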

Compound 3, half-maximal cytotoxic concentration: > 33000 nM
Compound 3: a limit, no number; the forecaster's own chance of this, stated with the estimate: 80%; the middle value is on the limit's open side.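

Compound 1 and compound 3 both give only a limit, not a number, so no step can be read between them. The compounds shown leave open whether isopropyl in place of 2-cyclopropylethyl changes the result in this assay.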